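Phenyl in Place of Hydroxy: An Expected Inhibition Value

A few compounds are considered here, and "the series" means these few. Any claim that something is new, unique, unknown or untested is made for them only; others in the source may bear on it.

Compound 1 `CCCCCc1c(C(C)C)nc(C(C)C)c(CO)c1-c1ccc(O)cc1` is the starting point of this account. In an assay on CHO cells for inhibition of Glucagon receptor (Homo sapiens), tested at 20 uM (on this read-out higher numbers stand for more inhibition at the one concentration tested (going by the name of the read-out) and lower numbers for less inhibition), compound 1 gives 24%, the lowest of the two numbers shown. Among the measured compounds shown here, its nearest neighbour, compound 2 `CCCCCc1c(C(C)C)nc(C(C)C)c(CO)c1-c1ccccc1C`, gives 33% in this assay; the only recorded step, a number 9 percentage points higher from compound 1 to compound 2 (within the scatter), corresponds to 2-methylphenyl in place of 4-hydroxyphenyl on an aromatic carbon. Compound 3 `CCCCCc1c(C(C)C)nc(C(C)C)c(CO)c1-c1ccc(-c2ccccc2)cc1` has not yet been measured. It differs from compound 1 by phenyl in place of hydroxy on an aromatic carbon, the place being para to a large group. For the measured compounds named here, no measured step tests this particular exchange; the single step available concerns a different replacement of the same aromatic substituent and was small. The expected step is therefore a number 11 percentage points higher from compound 1 to compound 3 (beyond the scatter), a change of modest size that may not exceed the scatter. The estimate for compound 3 in this assay is 35%, with a range from 10% to 60%.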

Compound 3, a percentage reported as inhibition, at one concentration (the size of the read-out at that concentration, not a potency): 2%
The estimate for compound 3 lay 33 percentage points above the measured number; the whole stated range lies above it.
By their numbers in this assay, from the lowest: compound 3; then compounds 1 and 2 (each within the scatter of the next).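

In this assay, the exchange of hydroxy for phenyl on an aromatic carbon, para to a large group, gives the only step shown that lies beyond the scatter, with a number 22 percentage points lower from compound 1 to compound 3 (beyond the scatter). The earlier step, a number 9 percentage points higher from compound 1 to compound 2 (within the scatter), changed the same aromatic substituent but stayed within the scatter, so it gave no sign that the number could fall this way. Here, one six-membered aromatic ring of carbon only enters, hydroxy leaves, and the number goes down rather than up; no measurement shown gives a reason for this.

The compounds shown leave open whether the lower number goes with the loss of hydroxy or with the arrival of phenyl. A methoxy group, an amine or a carboxylic acid at this place could help to tell these two apart.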